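Aryl ester variation: compound 1 to compound 4

The source may hold more compounds than are shown below. What is called first, only, known or untested is meant among the compounds shown, and "the series" means these compounds.

Compound 1 `COC(=O)c1cccc(Cl)c1OC(=O)COc1cc(O)c2c(=O)cc(-c3ccccc3)oc2c1` is the reference point of this set. Going by the values given here, in a functional assay on cells (T-cell, Mus musculus, strain BALB/c) for inhibition, read by MTT assay, with a stated time of 72 h (on this read-out lower numbers stand for stronger inhibition and higher numbers for weaker inhibition), compound 1 gives 38700 nM, the second highest of the three numbers so far; since every gap to the others lies within the scatter, nothing separates the three in potency. Among the compounds with values here, compound 2 `COC(=O)c1cccc(OC)c1OC(=O)COc1cc(O)c2c(=O)cc(-c3ccccc3)oc2c1` gives 36800 nM in this assay, and the single one-place step, a 1.1-fold lower number from compound 1 to compound 2 (0.02 log units; within the scatter), shows that exchanging the halogen for a methoxy on the aromatic carbon left the number where it was. Compound 3 `COC(=O)c1c(Br)cc(Br)cc1OC(=O)COc1cc(O)c2c(=O)cc(-c3ccccc3)oc2c1` gives 45700 nM in this assay; it is not a one-place neighbour of compound 1, and the two values simply sit within the scatter of each other.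

Compound 4 `COC(=O)c1cc(Br)ccc1OC(=O)COc1cc(O)c2c(=O)cc(-c3ccccc3)oc2c1` differs from compound 1 as follows: 4-bromo-2-(methoxycarbonyl)phenyl in place of 2-chloro-6-(methoxycarbonyl)phenyl on an oxygen next to a carbonyl group. Within the data shown here, only the step from compound 1 to compound 2 bears on this, and that one was flat; compound 3, with two bromines on the same ring, also gave nothing beyond the scatter. No measured change on this aryl ester has moved the read-out, so no step beyond the scatter is expected in this assay, with the estimated step of a 1.0-fold higher number from compound 1 to compound 4 (0.01 log units; within the scatter). Compound 4 is therefore estimated at 40000 nM, in the range 20000 nM to 80000 nM.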

Compound 4, half-maximal inhibitory concentration: 780 nM
For compound 4 the middle estimate is 51-fold (1.71 log units) above the measured one; measured number outside the range, below it.
By their numbers in this assay, from the lowest: compound 4; then compounds 2, 1 and 3 (each within the scatter of the next).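

Going by these compounds alone, the aryl ester is not a flat position in this assay: the exchange of 2-chloro-6-(methoxycarbonyl)phenyl for 4-bromo-2-(methoxycarbonyl)phenyl gives a 50-fold lower number from compound 1 to compound 4 (1.70 log units; beyond the scatter), while the only earlier one-place step, a 1.1-fold lower number from compound 1 to compound 2 (0.02 log units; within the scatter), showed no such movement, so the flat result for the swap of chloro for methoxy does not hold for every change on this ring. The new step keeps the size of the group, with the same count of heavy atoms, the same ring and the same count of hydrogen-bond acceptors on both sides, so the large move arises with the halogen and its place on the ring as the only differences between the two group names. Nothing at hand explains the step, and no independent measurement bears on it.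

The step changes the identity of the halogen and its place together, so the compounds shown do not tell which of the two carries the effect; 4-chloro-2-(methoxycarbonyl)phenyl and 2-bromo-6-(methoxycarbonyl)phenyl would separate them. Also open, as far as these compounds go, is whether the methyl ester matters to the low number of compound 4 780 nM, which a carboxylic acid or an amide in its place on the same ring would test.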